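A few compounds are considered here, and "the series" means these few. Any claim that something is new, unique, unknown or untested is made for them only; others in the source may bear on it.

In a functional assay on PC-3 cells (Homo sapiens) for inhibition, read by CellTiter-Glo, with a stated time of 72 h (a higher number here means that more compound is tolerated, a lower number that less compound is tolerated), compound 1 `CC1=C(CC(=O)N(C)CCN(C)C(=O)[C@@H](N)C(C)C)c2cc(F)ccc2/C1=C\c1ccc([S+](C)[O-])cc1` gives > 50000 nM, which is a limit of the assay and not a number. Compound 2 `CC1=C(CC(=O)N(C)CCN(C)S(C)(=O)=O)c2cc(F)ccc2/C1=C\c1ccc([S+](C)[O-])cc1` reads 42600 nM and compound 3 `CC1=C(CC(=O)N(C)CCN(C)S(=O)(=O)c2ccc(C)cc2)c2cc(F)ccc2/C1=C\c1ccc([S+](C)[O-])cc1` reads 11000 nM, so compound 3 holds the lower of the two numbers. Compound 4 `CC1=C(CC(=O)N(C)CCN(C)S(=O)(=O)c2ccc3ccccc3c2)c2cc(F)ccc2/C1=C\c1ccc([S+](C)[O-])cc1` carries naphthalen-2-yl in place of 4-methylphenyl on a sulfonyl sulfur.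

The closest measured precedent is the change at the same sulfonyl sulfur that gave compound 3, a 3.9-fold lower number from compound 2 to compound 3 (0.59 log units; beyond the scatter). The steps from compound 1 are floors only and give no size: an at least 1.1-fold lower number from compound 1 to compound 2 (0.06 log units; that floor lies within the scatter) and an at least 4.5-fold lower number from compound 1 to compound 3 (0.65 log units; beyond the scatter). With a single exact step at this place, any trend rests on one pair. A further modest fall in this assay is expected, smaller than the step that gave compound 3 a 3.9-fold lower number from compound 2 to compound 3 (0.59 log units; beyond the scatter). The expected change is a 2.2-fold lower number from compound 3 to compound 4 (0.34 log units; beyond the scatter). Compound 4 is estimated at 5000 nM, with an expected range of 1800 nM to 14000 nM.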

Compound 4, half-maximal cytotoxic concentration: 7520 nM
Beside the measured number, compound 4's estimate is 1.5-fold (0.18 log units) below it, and the stated range covers the measured number.
By their numbers in this assay, from the lowest: compounds 4 and 3 (each within the scatter of the next); then compound 2. At a limit, above all of these: compound 1.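

In this assay, enlarging the group on the sulfonyl sulfur from 4-methylphenyl to naphthalen-2-yl, one six-membered aromatic ring to two, gives a 1.5-fold lower number from compound 3 to compound 4 (0.17 log units; within the scatter), so the second ring brings no readable change at this position. Measured from methyl, naphthalen-2-yl gives a 5.7-fold lower number from compound 2 to compound 4 (0.75 log units; beyond the scatter), and set with a 3.9-fold lower number from compound 2 to compound 3 (0.59 log units; beyond the scatter), this shows that the step away from methyl is shared by both aromatic groups and is not particular to 4-methylphenyl. No measurement shown accounts for these steps.

Still open, from the compounds shown here alone, is whether a saturated ring such as cyclohexyl on the sulfonyl sulfur would read with methyl or with the two aromatic groups. Also open, going by these compounds, is how a carboxylic acid or an amine on the aromatic ring would read in this assay.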